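A few compounds are considered here, and "the series" means these few. Any claim that something is new, unique, unknown or untested is made for them only; others in the source may bear on it.

Measured so far:
- compound 1 `COc1cc(CNC(=O)CCCC/C=C/C(C)C)ccc1OC(=O)CCC(=O)Oc1ccc(C(N)=S)cc1` sits at the limit > 50000 nM in a functional assay on HeLa cells (Homo sapiens) for antiproliferative activity, read by MTT assay, with a stated time of 48 h; a higher number here means a weaker inhibitor, a lower number a stronger inhibitor.
- compound 2 `COc1cc(CNC(=O)CCCC/C=C/C(C)C)ccc1OCCCCOc1ccc(-c2cc(=S)ss2)cc1` gives 47100 nM in this assay.
- compound 3 `COc1cc(CNC(=O)CCCCCCC(C)C)ccc1OC(=O)CCC(=O)Oc1ccc(C(N)=S)cc1` sits at the limit > 50000 nM in this assay.

Compound 2 is the only one of the three with a number; the other two values are limits. The difference between the core of compound 1 and the core of compound 2 is not broken down here. From compound 1 to compound 3 the change is isopentyl in place of 3-methylbut-1-en-1-yl on a saturated chain carbon, four bonds along the chain from a carbonyl carbon, and the step that the two limits leave unreadable from compound 1 to compound 3 cannot be read because of the limit of > 50000 nM in this assay, at which 2 of the 3 values shown sit.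

Compound 4 `COc1cc(CNC(=O)CCCCCCC(C)C)ccc1OCCCCOc1ccc(-c2cc(=S)ss2)cc1` is not yet measured. It carries the same change as compound 3 carries against compound 1, namely (isopentyl in place of 3-methylbut-1-en-1-yl on a saturated chain carbon, four bonds along the chain from a carbonyl carbon), set on the core of compound 2, at the same place on the chain.

Compound 4 is expected to give about 55000 nM in this assay, with a likely range from 25000 nM to 120000 nM. The expected step of a 1.2-fold higher number from compound 2 to compound 4 (0.07 log units; within the scatter) is taken as small. One reason is that the same change gave the step that the two limits leave unreadable from compound 1 to compound 3, from which no direction can be read. Another is that compound 2 already stands at a weak level with 47100 nM.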

Compound 4, half-maximal inhibitory concentration: 44700 nM
Compound 4: the middle estimate sits 1.2-fold (0.09 log units) above what was measured; measured number inside the range.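

Isopentyl in place of 3-methylbut-1-en-1-yl gives, in this assay, a 1.1-fold lower number from compound 2 to compound 4 (0.02 log units; within the scatter), so on the core of compound 2 the double bond in this chain makes no readable difference. Among the compounds shown here, this does not show that the change carries over from one core to the other, since the step from compound 1 to compound 3 cannot be read and there is no second step to compare: the limit of > 50000 nM in this assay, at which 2 of the 4 values shown sit. Compound 2 and compound 4 also both stand at a weak level, so this single step within the scatter sets no rule for the series.

A longer chain, or an amine or a carboxylic acid in place of isopentyl, lies outside the compounds shown, so whether any change on this chain moves the number beyond the scatter in this assay stays open. Also open, from the compounds shown here alone, is the size of the same step on the core of compound 1, where both values are limits.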